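A Methyl on the Oxazole Side Chain of Compound 2

This account rests on a few compounds, and the source may have more. Where it says the series, first, only, none or still open, it means among the compounds named here.

Measured compounds:
compound 1, `CCC[C@H]1C[C@@H](OC)C/C(C)=C\[C@@H]2C[C@@H](OC(=O)CCCCc3coc(/C=C\CNC(=O)OC)n3)C[C@H](CC(=O)O1)O2`, 26 nM
compound 2, `C/C=C\c1nc(CC/C=C\C(=O)O[C@H]2C[C@@H]3CC(=O)O[C@@H](CCC)C[C@@H](OC)C/C(C)=C\[C@H](C2)O3)co1`, 440 nM
compound 3, `CCC[C@H]1C[C@@H](OC)C/C(C)=C\[C@@H]2C[C@@H](OC(=O)/C(C)=C\CCc3coc(/C=C\CNC(=O)OC)n3)C[C@H](CC(=O)O1)O2`, 2.6 nM

Three macrolides sharing one core have been measured in a functional assay on PANC-1 cells (Homo sapiens) for antiproliferative activity, read by WST assay, with a stated time of 96 h; a higher number here means a weaker inhibitor, a lower number a stronger inhibitor. Compound 3 gives the lowest number, 2.6 nM, and compound 1 follows with 26 nM. Compound 2 stands at the top of the three with 440 nM; its distance to compound 1 and its larger distance to compound 3 both lie beyond the usual scatter of this assay. For the measured compounds named here, compounds 1 and 3 differ from compound 2 in several places at once, so no single step between measured compounds can be read from the set.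

The unmeasured compound 4, `CCC[C@H]1C[C@@H](OC)C/C(C)=C\[C@@H]2C[C@@H](OC(=O)/C=C\CCc3coc(C=C(C)C)n3)C[C@H](CC(=O)O1)O2`, departs from compound 2 in exactly one place:

2-methylprop-1-en-1-yl in place of prop-1-en-1-yl on an aromatic carbon

The entire rest of the molecule, including the ester chain and the core, is kept. Going by the values given here, nothing among the measured compounds shows what this particular replacement does on its own. A modest step is therefore expected, most likely within the scatter, with no direction that can be argued from the data at hand. The expected step from compound 2 to compound 4 is a 1.3-fold lower number from compound 2 to compound 4 (0.10 log units; within the scatter). For compound 4 the estimate in this assay is 350 nM, with a range from 110 nM to 1100 nM.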

Compound 4, half-maximal inhibitory concentration: 2800 nM
Estimate against measurement, compound 4: 8.0-fold (0.90 log units) below; the whole stated range lies below it.
By their numbers in this assay, from the lowest: compound 3; then compound 1; then compound 2; then compound 4.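

In this assay, for the compounds shown here, replacing prop-1-en-1-yl with 2-methylprop-1-en-1-yl gives a 6.4-fold higher number from compound 2 to compound 4 (0.80 log units; beyond the scatter), a step beyond the usual scatter and the first single change that can be read. It shows that this aromatic carbon, next to the ring nitrogen and next to the ring oxygen, is not indifferent to a small enlargement of its group: the substituent goes only from 3 heavy atoms to 4, all carbon, with still no ring and 1 double bond outside aromatic rings, and the number rises. No measurement shown here gives a reason for this step.

What the compounds leave open is how the number responds to other groups on this same carbon, such as an ethyl, a cyclopropyl or a tert-butyl group, and so whether the rise follows from the added methyl alone or from any change to the alkene. On these data alone, it also remains open whether the same replacement would produce a step of similar size on the longer side chain ending in a methyl carbamate.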